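Acid Series: Swapping the Halogenated Amide Aryl

The source may report more compounds than this note shows. Statements on the series, on what has been measured and on what is new or still open speak of the compounds shown alone.

Among the measured compounds shown here, compound 2 `CN1CCN(c2ccc(Nc3nc(-c4cccc(NC(=O)c5cccc(F)c5)c4)sc3C(=O)O)cc2)CC1` stands highest of the two compounds measured so far: in a functional assay on Raji cells (Homo sapiens) for antiproliferative activity, read by CCK-8 assay, with a stated time of 72 h, tested at 40 uM (a lower number here means less inhibition, a higher number more inhibition at the concentration tested (going by the name of the read-out)), compound 2 gives 76.3%, while compound 1 `CCOC(=O)c1sc(-c2cccc(NC(=O)c3ccc(Cl)cc3)c2)nc1Nc1ccc(N2CCN(C)CC2)cc1` gives 24.3%, a gap well beyond the scatter. Compound 3 `CN1CCN(c2ccc(Nc3nc(-c4cccc(NC(=O)c5ccc(Cl)cc5)c4)sc3C(=O)O)cc2)CC1` keeps the shared core of compound 2 and differs only in the amide aryl group: 4-chlorophenyl in place of 3-fluorophenyl on a carbonyl carbon. For the measured compounds named here, no measured pair isolates this change, so its effect is unknown. The account expects compound 3 to stay near compound 2, with a step of a number 11.3 percentage points lower from compound 2 to compound 3 (beyond the scatter) that is small and downward. Compound 3 is therefore estimated at 65%, expected to fall between 40% and 85%.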

Compound 3, a percentage reported as inhibition, at one concentration (the size of the read-out at that concentration, not a potency): 90.9%
Compound 3: the middle estimate sits 25.9 percentage points below what was measured, outside the stated range (above it).
By their numbers in this assay, from the lowest: compound 1; then compound 2; then compound 3.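

Putting 4-chlorophenyl in place of 3-fluorophenyl on a carbonyl carbon gives a number 14.6 percentage points higher from compound 2 to compound 3 (beyond the scatter), showing that the number at this position moves upward with this change of amide aryl group. With 4-chlorophenyl held in place, hydrogen in place of ethyl on an oxygen next to a carbonyl group gives a number 66.6 percentage points higher from compound 1 to compound 3 (beyond the scatter), a large step. No measurement here offers an explanation for either step.

As far as these compounds go, the halogen and its place on the ring change together, so their separate contributions remain open. From the compounds shown here alone, how an amine or a methoxy group on this aryl ring would read also remains open.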